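Swapping the sulfonyl for a methyl on the piperazine

This account rests on a few compounds, and the source may have more. Where it says the series, first, only, none or still open, it means among the compounds named here.

Among the compounds with values here, compound 2 `CS(=O)(=O)N1CCN(Cc2cnc3c(Cn4cnc5cc(-c6ccc(Cl)cc6)sc5c4=O)cccc3c2)CC1` is one of two compounds measured in an assay on isolated protein for binding affinity to melanin-concentrating hormone receptor 1 (Homo sapiens), read by radioligand binding; a lower number here means a stronger inhibitor, a higher number a weaker inhibitor; in that assay compound 2 gives 773 nM, the higher of the two numbers. Within the data shown here, its only neighbour is compound 1 `CN(C)Cc1cnc2c(Cn3cnc4cc(-c5ccc(Cl)cc5)sc4c3=O)cccc2c1`, which in this assay gives 197 nM, and the step of a 3.9-fold higher number from compound 1 to compound 2 (0.59 log units; beyond the scatter) is the one recorded change, a modest rise upon replacing the dimethylamino group with the methylsulfonyl-capped piperazine.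

Compound 3 `CN1CCN(Cc2cnc3c(Cn4cnc5cc(-c6ccc(Cl)cc6)sc5c4=O)cccc3c2)CC1` has not been measured in this assay. It differs from compound 2 in one place: methyl in place of methylsulfonyl on an amine nitrogen in a ring. The only comparison that bears on this change is the step from compound 1 to compound 2, whose size is given above; removing the methylsulfonyl cap brings compound 3 closer to the pattern of compound 1, so part of that rise is expected to reverse.

Compound 3 is therefore expected to give a somewhat lower number than compound 2, estimated at 300 nM, with a range from 100 nM to 900 nM, corresponding to an expected step of a 2.6-fold lower number from compound 2 to compound 3 (0.41 log units; beyond the scatter).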

Compound 3, inhibition constant: 110 nM
Beside the measured number, compound 3's estimate is 2.7-fold (0.44 log units) above it; measured number inside the range.
By their numbers in this assay, from the lowest: compounds 3 and 1 (each within the scatter of the next); then compound 2.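

In this assay, the methylsulfonyl on the amine nitrogen of the piperazine proves to be the part that matters at this position: exchanging it for methyl gives a 7.0-fold lower number from compound 2 to compound 3 (0.85 log units; beyond the scatter). The ring itself shows no separable effect, since 4-methylpiperazin-1-yl in place of dimethylamino gives a 1.8-fold lower number from compound 1 to compound 3 (0.25 log units; within the scatter), which leaves compound 1 and compound 3 indistinguishable and ties the rise seen in a 3.9-fold higher number from compound 1 to compound 2 (0.59 log units; beyond the scatter) to the methylsulfonyl rather than to the exchange of dimethylamino for a piperazine. Nothing available here explains why the methylsulfonyl and methyl groups differ in this way.

The three compounds leave open whether the difference follows the sulfonyl group specifically or would also appear with another substituent on that nitrogen, such as an acetyl group, a longer alkyl chain such as ethyl or propyl, or a simple hydrogen. They also leave open whether a different ring at this place, such as morpholine or piperidine, would match compound 3 or compound 2, and whether the same ordering would hold on any other core.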